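Lengthening the basic amine chain on a cytotoxic urea

A few compounds are considered here, and "the series" means these few. Any claim that something is new, unique, unknown or untested is made for them only; others in the source may bear on it.

Measured compounds:
compound 1 `CN(C)CCNc1nc(-c2ccc(NC(=O)Nc3ccc(Cl)cc3)cc2)nc2ccsc12`: 310 nM
compound 2 `Cc1ccc(NC(=O)Nc2ccc(-c3nc(NCCN(C)C)c4sccc4n3)cc2)cc1`: 2180 nM

In a functional assay on MDA-MB-231 cells (Homo sapiens) for cytotoxicity, read by MTT assay, with a stated time of 72 h (a lower number here means a stronger inhibitor, a higher number a weaker inhibitor), compound 1 gives 310 nM and compound 2 gives 2180 nM. Compound 2 thus holds the higher of the two numbers, the weaker of the pair. Within the data shown here, the only measured step, a 7.0-fold higher number from compound 1 to compound 2 (0.85 log units; beyond the scatter), concerns a substituent on an aromatic ring, not the basic side chain.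

Compound 3 `CCN(CC)CCCNc1nc(-c2ccc(NC(=O)Nc3ccc(C)cc3)cc2)nc2ccsc12` differs from compound 2 by (diethylamino)methyl in place of dimethylamino on a saturated chain carbon, two bonds along the chain from a nitrogen on an aromatic ring. Among the measured compounds shown here, the side chain stayed the same between compound 1 and compound 2, so no measured step speaks to this change, and the data alone give no direction for it. The expected change, a 1.1-fold lower number from compound 2 to compound 3 (0.04 log units; within the scatter), is therefore none beyond the scatter, with wide uncertainty. Compound 3 is estimated at 2000 nM, within a range from 600 nM to 7000 nM.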

Compound 3, half-maximal inhibitory concentration: 1980 nM
The estimate for compound 3 lay 1.0-fold (0.00 log units) above the measured number; the measured number falls inside the stated range.
By their numbers in this assay, from the lowest: compound 1; then compounds 3 and 2 (each within the scatter of the next).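

Among these compounds, this is the first measured step on the side chain itself: exchanging (2-(dimethylamino)ethyl)amino for (3-(diethylamino)propyl)amino gives a 1.1-fold lower number from compound 2 to compound 3 (0.04 log units; within the scatter) in this assay. With the methyl-bearing urea kept in place, this position therefore accepts the longer chain and the larger amine with no change that can be told from assay scatter, unlike the substituent swap on the aromatic ring, which moved the number beyond the scatter. Nothing available here explains why the two side chains read alike.

Whether the same side-chain exchange would read alike with chloro in place of methyl remains open, since the compounds shown do not pair these two changes. Also open, from the compounds shown here alone, is how this position would respond to a cyclic amine such as morpholine or to a butyl chain.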